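From compound 3 to compound 4: a fluoro in place of hydrogen

The compounds below may be only part of what the source reports. "The series", "measured", "known", "first", "only" and "open" are said of these compounds alone.

In an ADME assay on Vero cells (Chlorocebus sabaeus) for cytotoxicity, read by MTT assay, with a stated time of 72 h (on this read-out lower numbers stand for higher toxicity in this test and higher numbers for lower toxicity in this test), compound 1 (`COc1c(N2C[C@H]3CCCN(Cc4cn(CCCN5C(=O)C(=O)c6ccccc65)nn4)[C@H]3C2)c(F)cc2c(=O)c(C(=O)O)cn(C3CC3)c12`) gives 16 ug/mL as its value, compound 2 (`COc1c(N2C[C@H]3CCCN(Cc4cn(CCCN5C(=O)C(=O)c6cc(C)ccc65)nn4)[C@H]3C2)c(F)cc2c(=O)c(C(=O)O)cn(C3CC3)c12`) gives 32 ug/mL as its value and compound 3 (`COc1c(N2C[C@H]3CCCN(Cc4cn(CCCN5C(=O)/C(=N/O)c6ccccc65)nn4)[C@H]3C2)c(F)cc2c(=O)c(C(=O)O)cn(C3CC3)c12`) gives 8 ug/mL as its value. The numbers show a 2.0-fold lower number from compound 1 to compound 3 (0.30 log units; within the scatter) and also a 4.0-fold lower number from compound 2 to compound 3 (0.60 log units; beyond the scatter) so compound 3 stands within the scatter of compound 1 but apart from compound 2. Compound 4 (`COc1c(N2C[C@H]3CCCN(Cc4cn(CCCN5C(=O)/C(=N/O)c6cc(F)ccc65)nn4)[C@H]3C2)c(F)cc2c(=O)c(C(=O)O)cn(C3CC3)c12`) differs from compound 3 by fluoro in place of hydrogen on an aromatic carbon. Among the compounds with values here, no fluoro step has been measured. The closest measured change is methyl in place of hydrogen on an aromatic carbon, which gives a 2.0-fold higher number from compound 1 to compound 2 (0.30 log units; within the scatter) and so stays within the scatter. Accordingly the expected change is no change at the digits printed from compound 3 to compound 4 (within the scatter) and no step beyond the scatter is anticipated. Compound 4 is expected at an estimated 8 ug/mL with a range from 4 ug/mL to 20 ug/mL when tested in this assay as the next measurement.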

Compound 4, half-maximal cytotoxic concentration: 2 ug/mL
Compound 4: middle estimate off by 4.0-fold (0.60 log units), on the high side, outside the stated range (below it).
By their numbers in this assay, from the lowest: compound 4; then compounds 3, 1 and 2 (each within the scatter of the next, the first and the last beyond it).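

In this assay, fluoro in place of hydrogen on an aromatic carbon gives a 4.0-fold lower number from compound 3 to compound 4 (0.60 log units; beyond the scatter), which shows that a change of a single heavy atom on this six-membered aromatic ring can move the number beyond the scatter. Within the data shown here, the only earlier step of this kind, methyl in place of hydrogen on an aromatic carbon, gave a 2.0-fold higher number from compound 1 to compound 2 (0.30 log units; within the scatter), so the earlier compounds did not show a ring substituent step of this size. Nothing measured here accounts for the new step.

The compounds shown leave open whether chloro or methoxy on this aromatic carbon would move the number as fluoro does. They also leave open whether fluoro would have the same effect in compound 1, which carries a carbonyl where compound 3 carries the oxime.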